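The compounds below may be only part of what the source reports. "The series", "measured", "known", "first", "only" and "open" are said of these compounds alone.

The measured compounds:

Compound 1 `C=C1C[C@]23C[C@@]1(O)CC[C@H]2c1ccc(OS(=O)(=O)c2ccc(C)cc2)c(C)c1[C@@H]3Cn1cc(-c2ccc(OC)cc2)nn1` gives in a functional assay on SW480 cells (Homo sapiens) for cytotoxicity, read by MTT assay, with a stated time of 4 days; on this read-out lower numbers stand for stronger inhibition and higher numbers for weaker inhibition > 20000 nM, which is a limit of the assay.
Compound 2 `C=C1C[C@]23C[C@@]1(O)CC[C@H]2c1cc(Br)c(O)c(C)c1[C@@H]3Cn1cc(-c2ccc(OC)cc2)nn1` gives in this assay > 20000 nM, likewise a limit.
Compound 3 `C=C1C[C@]23C[C@@]1(O)CC[C@@H]2c1cccc(C)c1[C@@H]3Cn1cc(-c2ccc(Br)cc2)nn1` gives in this assay > 20000 nM, again a limit.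

Compound 2 therefore does not stand at a number at all: its value is a limit, and it shares this limit with every other measured compound, as the limit of > 20000 nM in this assay, at which 3 of the 3 values shown sit, states. Within the data shown here, none of the three can be set apart from the others on these data, and no step between measured compounds is available.

Compound 4 `C=C1C[C@]23C[C@@]1(O)CC[C@H]2c1cc(Br)c(O)c(C)c1[C@@H]3Cn1cc(-c2ccccc2)nn1` differs from compound 2 in one place: hydrogen in place of methoxy on an aromatic carbon of the six-membered carbon-only ring, para to a large group. Among the measured compounds shown here, since no measured step is known, the expected size of the step in this assay is none beyond the usual scatter, in either direction. The step from compound 2 to compound 4 is expected to be a step that the limit leaves unreadable from compound 2 to compound 4. For compound 4 the estimate in this assay is 30000 nM, between 8000 nM and 100000 nM, with a strong chance that only a limit is reported again.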

Compound 4, half-maximal inhibitory concentration: > 20000 nM
Compound 4 gave a limit, no number; the forecaster's own chance of this, stated with the estimate: 85%; the middle value is on the limit's open side.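

In this assay compound 4 gives > 20000 nM, again a limit and not a number. No step between compound 2 and compound 4 can be read, as both compounds sit at the same limit: the limit of > 20000 nM in this assay, at which 4 of the 4 values shown sit.

The compounds shown leave open how strongly any of them acts in this assay, and whether exchanging methoxy for hydrogen changes that at all.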